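Replacing a methylpyrrolidine with a dimethylmorpholine on a urea

The source may report more compounds than this note shows. Statements on the series, on what has been measured and on what is new or still open speak of the compounds shown alone.

Measured compounds:
compound 1, `CC1CCN(C(=O)N2CC(c3nc(-c4cccc(Cl)c4)no3)C2)C1` — > 10000 nM
compound 2, `Cc1cccc(-c2noc(C3CN(S(=O)(=O)c4ccc(F)cc4)C3)n2)c1` — > 10000 nM

Compound 1 carries a 3-methylpyrrolidin-1-yl on its carbonyl carbon. In an assay on HEK293 cells for positive allosteric modulation of metabotropic glutamate receptor 5 (Homo sapiens), read by FLIPR (a lower number here means that less compound is needed, a higher number that more compound is needed for the effect), compound 1 gives only a limit, > 10000 nM, not a number. Compound 2, which bears a sulfonyl group in place of the urea, likewise reaches only a limit in this assay, > 10000 nM. Every value shown thus rests at the limit of > 10000 nM in this assay, at which 2 of the 2 values shown sit, so no ordering between the two measured compounds can be read.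

Compound 3, `CC1CN(C(=O)N2CC(c3nc(-c4cccc(Cl)c4)no3)C2)CC(C)O1`, differs from compound 1 in a single place: 2,6-dimethylmorpholin-4-yl in place of 3-methylpyrrolidin-1-yl on a carbonyl carbon. Going by the values given here, no step between measured compounds is available to anchor the size of this change. Given that compound 1 sits at the limit with > 10000 nM, the step that the limit leaves unreadable from compound 1 to compound 3 is expected to be none beyond the scatter. Compound 3 is therefore estimated to give 15000 nM, with a range of 3000 nM to 60000 nM, most likely reported again only as a limit.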

Compound 3, half-maximal effective concentration: > 10000 nM
Compound 3: no number, only a limit; the forecaster's own chance of this, stated with the estimate: 80%; the middle value does not contradict the limit.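

Going by these compounds alone, compound 3, like compound 1, gives only a limit, so no step between the two can be read: the limit of > 10000 nM in this assay, at which 3 of the 3 values shown sit.

The compounds shown leave open which structural change, if any, would give a measurable value in this assay.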